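The compounds below may be only part of what the source reports. "The series", "measured", "known", "first", "only" and "open" are said of these compounds alone.

Measured so far:
compound 1 `COc1ccc([C@@H]2CC(=O)c3c(O)cc(OCc4cn(Cc5cccc(Cl)c5)nn4)cc3O2)cc1O` — 18200 nM
compound 2 `COc1ccc([C@@H]2C/C(=N\O)c3c(O)cc(OCc4cn(Cc5ccccc5C)nn4)cc3O2)cc1O` — 18000 nM

In a functional assay on RAW264.7 cells (Mus musculus) for inhibition, read by Griess assay, with stated times of 2 h and 24 h (on this read-out higher numbers stand for weaker inhibition and lower numbers for stronger inhibition), compound 1 gives 18200 nM, the higher of the two numbers; compound 2 gives 18000 nM, and the two values sit within the usual scatter, so neither compound can be placed above the other. Compound 3 `COc1ccc([C@@H]2CC(=O)c3c(O)cc(OCc4cn(Cc5cccc(C#N)c5)nn4)cc3O2)cc1O` has not yet been measured. Its difference from compound 1 is cyano in place of chloro on an aromatic carbon. Among the measured compounds shown here, no step between measured compounds is available, so the data give no direction for this change. Compound 3 is expected to give about 20000 nM, between 8000 nM and 50000 nM. The expected step is a 1.1-fold higher number from compound 1 to compound 3 (0.04 log units; within the scatter), which stays within the scatter.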

Compound 3, half-maximal inhibitory concentration: 18000 nM
The estimate for compound 3 lay 1.1-fold (0.05 log units) above the measured number; the range from low to high includes it.
By their numbers in this assay, from the lowest: compounds 2, 3 and 1 (each within the scatter of the next).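

Among the compounds shown here, the step from 3-chlorobenzyl to 3-cyanobenzyl gives the first direct reading at this position: in this assay it amounts to a 1.0-fold lower number from compound 1 to compound 3 (0.00 log units; within the scatter). Cyano, with its triple bond and hydrogen-bond acceptor, therefore cannot be told apart from chloro at this place on the aromatic ring by this read-out. No available measurement explains why the two groups read alike. As far as these compounds go, what an amine or a carboxylic acid on this same aromatic carbon would give remains open, as does whether a group there could move the number beyond the scatter.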